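Adding a Methoxy to the Phenyl of Compound 2

The source may report more compounds than this note shows. Statements on the series, on what has been measured and on what is new or still open speak of the compounds shown alone.

Compound 2 `COc1cc(-c2cc(C(=O)/C=C/c3ccccc3)nc3cc(-c4ccccc4)nn23)cc(OC)c1OC` was tested in a functional assay on MDA-MB-231 cells (Homo sapiens) for antiproliferative activity, read by MTT assay, with a stated time of 24 h (a lower number here means a stronger inhibitor, a higher number a weaker inhibitor), where compound 2 gives 19200 nM. Among the three compounds measured so far, compound 2 has the second highest number. Compound 1 `COc1ccc(-c2cc(C(=O)/C=C/c3ccccc3)nc3cc(-c4ccccc4)nn23)cc1OC` gives 23300 nM, a gap within the scatter, while compound 3 `COc1ccc(-c2cc(/C=C/C(=O)c3ccc(OC)c(OC)c3)nc3cc(-c4ccccc4)nn23)cc1` gives 8700 nM, a gap that lies beyond the scatter.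

Compound 4 `COc1ccc(/C=C/C(=O)c2cc(-c3cc(OC)c(OC)c(OC)c3)n3nc(-c4ccccc4)cc3n2)cc1` differs from compound 2 in one place: methoxy in place of hydrogen on an aromatic carbon. Within the data shown here, the only measured step of the same kind is a 1.2-fold lower number from compound 1 to compound 2 (0.08 log units; within the scatter), a methoxy added on a different ring, and it stayed within the scatter. Compound 3 differs from compound 2 in more than one place, so its lower number cannot be read as a single step of this change. No measured change on the ring touched here exists. A step within the scatter is therefore expected, a 1.3-fold lower number from compound 2 to compound 4 (0.11 log units; within the scatter). Compound 4 is estimated to give 15000 nM, with a range from 7000 nM to 32000 nM.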

Compound 4, half-maximal inhibitory concentration: 16500 nM
Estimate against measurement, compound 4: 1.1-fold (0.04 log units) below, within the range that was stated.
By their numbers in this assay, from the lowest: compounds 3, 4, 2 and 1 (each within the scatter of the next, the first and the last beyond it).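

The phenyl of the 2-phenylethenyl group now has a measured result of its own: in this assay, going to 2-(4-methoxyphenyl)ethenyl gives a 1.2-fold lower number from compound 2 to compound 4 (0.07 log units; within the scatter). Among these compounds, this is the first reading at this position, and it shows that hydrogen and methoxy here cannot be told apart in this test. The earlier methoxy step on a different ring, a 1.2-fold lower number from compound 1 to compound 2 (0.08 log units; within the scatter), was also within the scatter, so in these compounds the change has twice made no clear difference on two separate rings. No measurement is at hand that could explain this result.

Methoxy is the only group compared with hydrogen on this ring, so a single step says little about the position as a whole. An amine, a carboxylic acid or a longer chain such as butoxy in the same place could still move the number beyond the scatter.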